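This account rests on a few compounds, and the source may have more. Where it says the series, first, only, none or still open, it means among the compounds named here.

Three members of the series have been measured in a functional assay on a cell-free system (plasma) for inhibition of thromboxane A2 receptor (Homo sapiens), read by turbidimetry; a lower number here means a stronger inhibitor, a higher number a weaker inhibitor. Compound 1 `O=C(O)CC/C=C\CC1=CCC[C@@H]1NS(=O)(=O)c1ccc(Cl)c(Cl)c1` gives 1900 nM in this assay. Compound 2 `O=C(O)CC/C=C\CC1=CCC[C@@H]1NS(=O)(=O)c1ccc(Cl)cc1` gives 1900 nM in this assay, and compound 3 `O=C(O)CC/C=C\CC1=CCC[C@@H]1NS(=O)(=O)c1ccc(F)cc1` gives 1300 nM. On the numbers shown, compound 3 stands at the lowest figure of the three, but its separations from compound 1 and from compound 2 are each within the scatter, so the three compounds are not distinguished by this assay.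

Compound 4 `O=C(O)CC/C=C\CC1=CCC[C@@H]1NS(=O)(=O)c1ccccc1` has not been measured. It differs from compound 3 by hydrogen in place of fluoro on an aromatic carbon. Going by the values given here, two measured steps bear on this change, both at the same place on the six-membered aromatic ring of carbon only: no change at the digits printed from compound 1 to compound 2 (within the scatter) and a 1.5-fold lower number from compound 2 to compound 3 (0.16 log units; within the scatter). Neither moved the number beyond the scatter; hydrogen in place of chloro and fluoro in place of chloro each left the result in this assay essentially where it stood. The change from compound 3 to compound 4 is of the same kind, so no step beyond the scatter is expected in this assay, in either direction.

Compound 4 is therefore estimated at 1500 nM in this assay, with a range from 700 nM to 3200 nM. This estimate means an expected 1.2-fold higher number from compound 3 to compound 4 (0.06 log units; within the scatter).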

Compound 4, half-maximal inhibitory concentration: 2200 nM
Estimate against measurement, compound 4: 1.5-fold (0.17 log units) below, within the range that was stated.
By their numbers in this assay, from the lowest: compounds 3, 1, 2 and 4 (each within the scatter of the next).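

In this assay, the unsubstituted phenyl now gives a true baseline for this position: hydrogen in place of fluoro gives a 1.7-fold higher number from compound 3 to compound 4 (0.23 log units; within the scatter), hydrogen in place of chloro gives a 1.2-fold higher number from compound 2 to compound 4 (0.06 log units; within the scatter), and phenyl in place of 3,4-dichlorophenyl gives a 1.2-fold higher number from compound 1 to compound 4 (0.06 log units; within the scatter). The earlier steps shown here only exchanged one halogen pattern for another, whereas these show that a fluoro or chloro on the aromatic carbon para to a large group, and the 3,4-dichlorophenyl pattern, are each not distinguished from having no substituent at all in this assay. No supporting measurement is available to explain this flat result.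

From the compounds shown here alone, all four compounds carry only hydrogen or halogen on the six-membered aromatic ring, so it remains open whether a methoxy, a nitro, an amine or a carboxylic acid at that place would move the number beyond the scatter. The shared core and the acid-bearing chain are also constant throughout, which leaves open whether a longer chain or an amide in place of the carboxylic acid would separate compounds that this ring position does not.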